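This account rests on a few compounds, and the source may have more. Where it says the series, first, only, none or still open, it means among the compounds named here.

Working notes on the series. Among the compounds with values here, compound 2 `ClCc1ccccc1Cn1cnc2c(Cl)nc(Cl)nc21` is the anchor: in a functional assay on SW-620 cells (Homo sapiens) for cytotoxicity, read by sulforhodamine B assay, with a stated time of 48 h (on this read-out higher numbers stand for weaker inhibition of growth and lower numbers for stronger inhibition of growth), compound 2 gives 350 nM, and that is the only number in hand. Compound 1 `ClCc1ccc(Cn2cnc3c(Cl)ncnc32)cc1` belongs to the same set, but in this assay compound 1 gives "not determined" (no result reported), so it carries no weight for comparison. Compound 3 `ClCc1ccccc1Cn1cnc2c(Cl)ncnc21` is the next entry to be read.

The change from compound 2 to compound 3 is hydrogen in place of chloro on an aromatic carbon — hydrogen in place of chloro on an aromatic carbon, with the rest of the molecule held constant. Within the data shown here, no pair of measured compounds shows a step of this kind, so there is no internal calibration for it; the size and direction of the effect are open. With a single reference point, the working expectation is a modest weakening rather than a gain, held close enough to the scatter that the outcome could go either way.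

On that basis, the step from compound 2 to compound 3 is expected to be a 2.0-fold higher number from compound 2 to compound 3 (0.30 log units; within the scatter). Compound 3 is estimated at 700 nM, with a range from 200 nM to 3000 nM, pending the measurement.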

Compound 3, concentration for total growth inhibition: 5010 nM
Compound 3: the middle estimate sits 7.2-fold (0.85 log units) below what was measured; measured number outside the range, above it.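

In this assay, the aromatic carbon between two ring nitrogen atoms is not a neutral place: hydrogen in place of chloro there gives a 14-fold higher number from compound 2 to compound 3 (1.16 log units; beyond the scatter), and the higher number stands for weaker inhibition of growth. Within the data shown here, this is the first calibrated step, and it shows that the chloro group at this position goes with the stronger value of the pair, though it rests on one matched pair with the rest of the molecule held constant. No supporting data bear on why the step is this large, so it stands as an observation only.

The compounds shown leave open whether this value depends on chloro itself or would also be held by an amine, a methoxy group or a methyl group on the same carbon. Going by these compounds, whether the step carries over to the arrangement of the chloromethyl group seen in compound 1 also stays open, and steps involving compound 1 cannot be read.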